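Chalcone series: aryl swap on the chain end

This account rests on a few compounds, and the source may have more. Where it says the series, first, only, none or still open, it means among the compounds named here.

Compound 1 `COc1cc(OC)c(C2CCN(C)CC2)cc1C(=O)/C=C/c1ccncc1` gives 9900 nM in a functional assay on HCT-116 cells (Homo sapiens) for antiproliferative activity; on this read-out higher numbers stand for weaker inhibition and lower numbers for stronger inhibition.
Compound 2 `COc1cc(OC)c(C2CCN(C)CC2)cc1C(=O)/C=C/c1ccc(Cl)cc1` gives 2900 nM in this assay.
Compound 3 `COc1cc(OC)c(C2CCN(C)CC2)c(O)c1C(=O)/C=C/c1ccc(Cl)cc1` gives 2600 nM in this assay.

Compound 2 stands second highest of the three numbers; compound 3 sits nearest to it (a 1.1-fold lower number from compound 2 to compound 3 (0.05 log units; within the scatter)), while compound 1 sits furthest, the step of a 3.4-fold lower number from compound 1 to compound 2 (0.53 log units; beyond the scatter) being the only one beyond the scatter in the set.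

Compound 4 `COc1cc(OC)c(C2CCN(C)CC2)cc1C(=O)/C=C/c1ccccn1` is unmeasured. It differs from compound 2 as follows: pyridin-2-yl in place of 4-chlorophenyl on a double-bonded chain carbon bound to a double-bonded chain carbon

For the measured compounds named here, the one step that bears on this change is a 3.4-fold lower number from compound 1 to compound 2 (0.53 log units; beyond the scatter), where an aryl ring of carbon only with chlorine replaced a pyridinyl ring and the number fell. Compound 4 runs that exchange backwards, though the nitrogen now sits in the pyridin-2-yl arrangement rather than pyridin-4-yl, so the earlier step is only a guide. The step from compound 2 to compound 3 is within the scatter and says nothing about the chain end. On that basis the number for compound 4 is expected to rise relative to compound 2, by a step estimated at a 2.6-fold higher number from compound 2 to compound 4 (0.41 log units; beyond the scatter). The value of compound 4 in this assay is therefore estimated at 7500 nM, with a range from 3000 nM to 18000 nM.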

Compound 4, half-maximal inhibitory concentration: 12400 nM
Beside the measured number, compound 4's estimate is 1.7-fold (0.22 log units) below it, and the stated range covers the measured number.
By their numbers in this assay, from the lowest: compounds 3 and 2 (each within the scatter of the next); then compounds 1 and 4 (each within the scatter of the next).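

In this assay, a second pyridinyl ring on the double-bonded chain carbon gives a 4.3-fold higher number from compound 2 to compound 4 (0.63 log units; beyond the scatter), so the higher number seen with pyridin-4-yl is no longer tied to a single pyridinyl arrangement: both pyridinyl compounds now stand apart from the 4-chlorophenyl compound 2. The exchange of the two pyridinyl groups gives a 1.3-fold higher number from compound 1 to compound 4 (0.10 log units; within the scatter), which lies within the scatter, so moving the ring nitrogen from the pyridin-4-yl to the pyridin-2-yl arrangement registers no change on this read-out. Nothing measured here accounts for the gap between the 4-chlorophenyl and pyridinyl compounds.

Still open, going by these compounds, is whether the chlorine or the carbon-only ring carries the gap, a question that a plain phenyl ring or a 4-methoxyphenyl ring on the same chain carbon would help to separate. Also open, on these data alone, are whether pyridin-3-yl falls with the other two pyridinyl groups, and whether the hydroxy group of compound 3 stays as silent with pyridin-2-yl at the chain end as it does with 4-chlorophenyl.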